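Moving the fluorine on the aryl group of compound 2

A few compounds are considered here, and "the series" means these few. Any claim that something is new, unique, unknown or untested is made for them only; others in the source may bear on it.

Measured so far:
- compound 1, `c1ccc2c(-c3cn4ccnc4c(-c4ccc5ncn(C6CCCCC6)c5c4)n3)cccc2c1`: 9.08%
- compound 2, `Fc1ccc(-c2cn3ccnc3c(-c3ccc4ncn(C5CCCCC5)c4c3)n2)cc1`: 14.2%

Both compounds were tested in a functional assay on SNB-19 cells (Homo sapiens) for inhibition, read by sulforhodamine B assay, with a stated time of 48 h, tested at 10 uM; a lower number here means less inhibition, a higher number more inhibition at the concentration tested (going by the name of the read-out). In this assay compound 1 gives 9.08% and compound 2 gives 14.2%. Going by the values given here, the one step between them, a number 5.1 percentage points higher from compound 1 to compound 2 (within the scatter), is within the scatter, so the two numbers cannot be told apart; both show weak inhibition at the concentration tested.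

Compound 3, `Fc1ccccc1-c1cn2ccnc2c(-c2ccc3ncn(C4CCCCC4)c3c2)n1`, differs from compound 2 only in where the fluorine sits on the aryl group: 2-fluorophenyl in place of 4-fluorophenyl on an aromatic carbon. Among the compounds with values here, no measured step changes the position of a substituent on this aryl group, so nothing bears directly on the change. Within the data shown here, the only step known, from a naphthalen-1-yl to a 4-fluorophenyl group, stayed within the scatter, and both measured compounds sit at weak inhibition.

Compound 3 is therefore expected to stay near compound 2, with a step of a number 2.2 percentage points lower from compound 2 to compound 3 (within the scatter), not beyond the scatter. The estimate for compound 3 in this assay is 12%, between 2% and 26%.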

Compound 3, a percentage reported as inhibition, at one concentration (the size of the read-out at that concentration, not a potency): 7.56%
For compound 3 the middle estimate is 4.4 percentage points above the measured one; low and high end bracket the measured number.
By their numbers in this assay, from the lowest: compounds 3, 1 and 2 (each within the scatter of the next).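

Going by these compounds alone, this is the first step that moves the fluorine on the aryl group while leaving everything else alone. In this assay, 2-fluorophenyl in place of 4-fluorophenyl gives a number 6.6 percentage points lower from compound 2 to compound 3 (within the scatter), so these numbers show no effect of the fluorine's position that can be told apart from ordinary scatter. 2-Fluorophenyl in place of naphthalen-1-yl gives a number 1.5 percentage points lower from compound 1 to compound 3 (within the scatter), which places all three aryl groups shown, the naphthalen-1-yl and both fluorophenyl groups, together at weak inhibition at the one concentration tested. No separate measurement is available that could explain these results.

The compounds shown leave open whether any group at this place on the shared core can lift inhibition clearly beyond the scatter, for example an aryl ring carrying an amine or a carboxylic acid instead of fluorine. They also leave open whether a change elsewhere, such as a shorter chain or a piperidine in place of the cyclohexyl group, would do more than any change of the aryl group seen so far.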